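Replacing pyrrolidin-1-yl on the shared core

This account rests on a few compounds, and the source may have more. Where it says the series, first, only, none or still open, it means among the compounds named here.

This small series is read in a functional assay on MCF7 cells (Homo sapiens) for antiproliferative activity (on this read-out higher numbers stand for weaker inhibition and lower numbers for stronger inhibition), as its only test. Compound 1 `COc1ccc(C(=O)Nc2ccc(O)c3c(=O)cc(-c4ccccc4Cl)oc23)cc1` gives 3500 nM there, and compound 3 `CSCC[C@@H](NC(=O)OC(C)(C)C)C(=O)Nc1ccc(O)c2c(=O)cc(-c3ccccc3Cl)oc12` gives 2800 nM on the same read-out. These two values lie within the usual scatter of each other. Compound 2 `O=c1cc(-c2ccccc2Cl)oc2c(N3CCCC3)ccc(O)c12` gives 20000 nM as the highest number of the three, which makes it the weakest inhibitor here, with its gaps to both others beyond the scatter.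

Compound 4 `CCC(C)OC(=O)Nc1ccc(O)c2c(=O)cc(-c3ccccc3Cl)oc12` has not yet been measured. The change from compound 2 is (sec-butoxycarbonyl)amino in place of pyrrolidin-1-yl on an aromatic carbon with (sec-butoxycarbonyl)amino in place of pyrrolidin-1-yl on an aromatic carbon, para to a hydroxy group. Going by the values given here, no two measured compounds differ in one place only, so the expectation rests on three values alone. Compound 4 keeps a carbonyl on the nitrogen at that carbon, as compound 1 at 3500 nM and compound 3 at 2800 nM do, so a drop in the number in this assay beyond the scatter is expected. The estimated step is a 5.0-fold lower number from compound 2 to compound 4 (0.70 log units; beyond the scatter) in the direction of stronger inhibition. Compound 4 is estimated at 4000 nM with an expected range from 1500 nM to 11000 nM on this limited evidence.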

Compound 4, half-maximal inhibitory concentration: 30000 nM
Compound 4: the middle estimate sits 7.5-fold (0.88 log units) below what was measured; measured number above the stated range.
By their numbers in this assay, from the lowest: compounds 3 and 1 (each within the scatter of the next); then compounds 2 and 4 (each within the scatter of the next).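

In this assay, the step (a 1.5-fold higher number from compound 2 to compound 4 (0.18 log units; within the scatter)) shows that a carbonyl on the nitrogen at this aromatic carbon, para to a hydroxy group, does not on its own set (sec-butoxycarbonyl)amino apart from pyrrolidin-1-yl, so compound 4 goes against the link between that carbonyl and the lower numbers of compounds 1 and 3. The group carried on the carbonyl matters at least as much as the carbonyl itself, since sec-butoxy in place of 4-methoxyphenyl on a carbonyl carbon gives a step beyond the scatter (an 8.6-fold higher number from compound 1 to compound 4 (0.93 log units; beyond the scatter)). Nothing in the data shown gives a reason for either step.

The compounds shown leave open which part of 4-methoxyphenyl carries that step, and an unsubstituted phenyl or a short methyl group on the same carbonyl would begin to separate the aromatic ring and the methoxy group from the mere presence of a carbonyl. A free primary amine at this aromatic carbon would also show how the nitrogen behaves with no carbonyl and no ring attached, a case that neither compound 2 nor compound 4 covers.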